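Methylpyrimidine for fluoropyrimidine: a microsomal stability comparison

This account rests on a few compounds, and the source may have more. Where it says the series, first, only, none or still open, it means among the compounds named here.

Measured compounds:
Compound 1, `Fc1ncncc1Cn1nc(-c2nc(C(F)(F)F)n[nH]2)c2cccnc21`: < 11 mL.min-1.g-1 in an in vitro ADME assay on microsomes from liver (Homo sapiens) for metabolic stability; on this read-out higher numbers stand for fast clearance and lower numbers for slow clearance
Compound 2, `Fc1ccccc1Cc1nc(-c2nc(C(F)(F)F)n[nH]2)n2cccnc12`: 17 mL.min-1.g-1 in this assay

Of the compounds shown here, two have been measured in this assay. For compound 1 the result is not a number but a limit of the assay, < 11 mL.min-1.g-1. Compound 2, which shares the trifluoromethyl-triazole and the benzylic attachment but differs in its core and in its aryl group, gives 17 mL.min-1.g-1. Compound 1 therefore sits at the floor of what the assay reports (the limit of < 11 mL.min-1.g-1 in this assay, at which 1 of the 2 values shown sits), and nothing finer than that can be said of where it stands.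

The next compound, compound 3, `Cc1ncc(Cn2nc(-c3nc(C(F)(F)F)n[nH]3)c3cccnc32)cn1`, keeps the whole of compound 1 except for one exchange: 2-methylpyrimidin-5-yl in place of 4-fluoropyrimidin-5-yl on a saturated chain carbon bound to an aromatic nitrogen. Among the compounds with values here, since only a limit is known for compound 1, no step from it to compound 3 can be set against a measured one. The expectation is that the step of an at least 1.0-fold higher number from compound 1 to compound 3 (0.03 log units; that floor lies within the scatter) stays small, within the usual scatter, and that compound 3 may again sit at or near the floor of this assay. Compound 3 is accordingly estimated at 12 mL.min-1.g-1, with a range from 5 mL.min-1.g-1 to 30 mL.min-1.g-1.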

Compound 3, intrinsic clearance in microsomes: < 7 mL.min-1.g-1
Compound 3: only a limit was reported (the forecaster's own chance of this, stated with the estimate: 45%); at least 1.7-fold (0.23 log units) between middle value and limit.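

The results for compound 1 and compound 3 in this assay are both limits of the assay, and the step between them cannot be read. The compounds shown leave open how far the clearance of either compound lies under its limit, and whether 2-methylpyrimidin-5-yl in place of 4-fluoropyrimidin-5-yl changes that clearance at all.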